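The source may report more compounds than this note shows. Statements on the series, on what has been measured and on what is new or still open speak of the compounds shown alone.

Measured in a functional assay on HL-60 cells (Homo sapiens) for inhibition; a lower number here means a stronger inhibitor, a higher number a weaker inhibitor:
Compound 1 `OC[C@H]1OC(n2cnc3c(-c4ccoc4)ncnc32)[C@H](O)[C@@H]1O`: 3300 nM
Compound 2 `OC[C@H]1OC(n2cnc3c(-c4ccc(F)cc4)ncnc32)[C@H](O)[C@@H]1O`: 6300 nM

Within the data shown here, only these two compounds have numbers so far, and compound 1 cannot be separated from compound 2, since the measured step is a 1.9-fold higher number from compound 1 to compound 2 (0.28 log units; within the scatter). Compound 3 `OC[C@H]1OC(n2cnc3c(-c4ccc(O)cc4)ncnc32)[C@H](O)[C@@H]1O` keeps the core of compound 1 but carries 4-hydroxyphenyl in place of furan-3-yl on an aromatic carbon. Among the measured compounds shown here, the only measured step that bears on this change is the one above, which puts 4-fluorophenyl in the same place. For the measured compounds named here, it is a single step with a different group, and no hydroxyphenyl compound has been measured yet. No step beyond the scatter is therefore expected in this assay, with a slight lean towards a higher number. For compound 3 the expected value is 5500 nM, with an estimated range from 1800 nM to 17000 nM. This estimate means an expected 1.7-fold higher number from compound 1 to compound 3 (0.22 log units; within the scatter).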

Compound 3, half-maximal inhibitory concentration: 7600 nM
Compound 3: the middle estimate sits 1.4-fold (0.14 log units) below what was measured; low and high end bracket the measured number.
By their numbers in this assay, from the lowest: compounds 1, 2 and 3 (each within the scatter of the next, the first and the last beyond it).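

In this assay, among these compounds, 4-hydroxyphenyl in place of furan-3-yl on the aromatic carbon gives the first step at this position that lies beyond the scatter, though only modestly (a 2.3-fold higher number from compound 1 to compound 3 (0.36 log units; beyond the scatter)). Hydroxy in place of fluoro on the six-membered aromatic ring of carbon only leaves compound 2 and compound 3 inseparable (a 1.2-fold higher number from compound 2 to compound 3 (0.08 log units; within the scatter)). Compound 1 thus stands apart from compound 3 but not from compound 2, so the two substituted phenyl compounds do not separate cleanly from furan-3-yl as a pair, and no measurement offered here accounts for the step.

From the compounds shown here alone, whether an amine or a carboxylic acid in place of the hydroxy on that ring would shift the number remains open. So does the effect of a non-aromatic group at this position, such as a short alkyl chain.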